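A Chlorine Added to a Growth-Inhibiting Scaffold

The source may report more compounds than this note shows. Statements on the series, on what has been measured and on what is new or still open speak of the compounds shown alone.

Of the compounds shown here, two have been tested so far in a functional assay on T47D cells (Homo sapiens) for inhibition, read by sulforhodamine B assay, with a stated time of 48 h, tested at 10 uM; on this read-out higher numbers stand for more inhibition of growth at the one concentration tested and lower numbers for less inhibition of growth. Compound 1, `COc1cc(-c2nc(N)n(CC(=O)Nc3ccc(/C(C)=N\O)cc3)n2)cc(OC)c1OC`, gives 8.77%. Compound 2, `c1ccc(-c2nc3sc(-c4ccccc4)cn3n2)cc1`, gives 63%, the higher of the two numbers. The gap between compound 2 and compound 1 lies beyond the usual scatter of such measurements. The two structures do not differ in only one place, so their numbers stand as two separate readings rather than as a step.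

Compound 3, `Clc1ccc(-c2cn3nc(-c4ccccc4)nc3s2)cc1`, has not yet been measured. It differs from compound 2 by a single change: chloro in place of hydrogen on an aromatic carbon. Seen one bond further out, a phenyl becomes a 4-chlorophenyl. Within the data shown here, no measured pair shows what this change does here, so the expectation rests on compound 2 alone. In this assay the expected step of a number 2 percentage points higher from compound 2 to compound 3 (within the scatter) is small and not beyond the scatter. Compound 3 is therefore estimated at 65%, within a range from 45% to 82%.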

Compound 3, percent growth inhibition at one concentration: 74%
Compound 3: middle estimate off by 9 percentage points, on the low side; measured number inside the range.
By their numbers in this assay, from the lowest: compound 1; then compound 2; then compound 3.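

Putting chloro in place of hydrogen on an aromatic carbon, para to a large group, gives in this assay a number 11 percentage points higher from compound 2 to compound 3 (beyond the scatter). Among these compounds, this is the first step measured on this core, and it shows that this position can carry a chlorine without any loss of growth inhibition; the 4-chlorophenyl compound in fact stands higher than the plain phenyl. Nothing available explains why the number rises with this change.

The compounds shown leave open whether a fluoro, a methoxy, an amine or a carboxylic acid on the same carbon would match chloro, fall short of it or go beyond it. They also leave open whether the same change on the other phenyl, which stays unchanged here, would give a similar step.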